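Trading Methoxy for Methyl: An Expected Cytotoxicity Step

A few compounds are considered here, and "the series" means these few. Any claim that something is new, unique, unknown or untested is made for them only; others in the source may bear on it.

For the measured compounds named here, compound 1 `COc1cccc2c(=O)cc(/C=C/[S+](C)[O-])oc12` is the only member of this small set with a numerical result in a functional assay on A549 cells (Homo sapiens) for cytotoxicity, with a stated time of 48 h (on this read-out higher numbers stand for weaker inhibition and lower numbers for stronger inhibition), where compound 1 gives 2200 nM. Compound 2 `C[S+]([O-])/C=C/c1cc(=O)c2cc(C#N)ccc2o1` returns only a limit in this assay, > 10000 nM, which is the point at which one of the two shown values sits (the limit of > 10000 nM in this assay, at which 1 of the 2 values shown sits). Compound 3 `Cc1cccc2c(=O)cc(/C=C/[S+](C)[O-])oc12` differs from compound 1 by a single change: methyl in place of methoxy on an aromatic carbon. Going by the values given here, no measured pair shows this change, so the step is expected to be small and within the usual scatter: a 1.4-fold higher number from compound 1 to compound 3 (0.13 log units; within the scatter). Compound 3 is therefore expected to give 3000 nM, with a range from 1000 nM to 9000 nM.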

Compound 3, half-maximal inhibitory concentration: 1700 nM
Compound 3: middle estimate off by 1.8-fold (0.25 log units), on the high side, and the stated range covers the measured number.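

For the compounds shown here, the swap of methoxy for methyl gives a 1.3-fold lower number from compound 1 to compound 3 (0.11 log units; within the scatter) in this assay, and this is the first measured pair at this position. At this aromatic carbon, then, losing the oxygen of the methoxy group leaves the read-out unchanged within the scatter. Nothing shown here bears on why the two groups read alike. Still open, from the compounds shown here alone, is whether a group of another kind at this position, such as an amine, a carboxylic acid or a longer chain, would shift the number beyond the scatter.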